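Adding Chloro to the Urea Aryl Ring of Compound 3

The source may hold more compounds than are shown below. What is called first, only, known or untested is meant among the compounds shown, and "the series" means these compounds.

Measured so far:
compound 1 `O=C(Nc1cccc(-n2cc(-c3ccncc3)c(-c3ccc(Cl)c(O)c3)n2)c1)Nc1cccc(C(F)(F)F)c1` gives 1820 nM in a functional assay on SR cells (Homo sapiens) for inhibition, read by sulforhodamine B assay, with a stated time of 48 h; a lower number here means a stronger inhibitor of growth, a higher number a weaker inhibitor of growth
compound 2 `COc1cc(-c2nn(-c3cccc(NC(=O)Nc4cc(C(F)(F)F)cc(C(F)(F)F)c4)c3)cc2-c2ccncc2)ccc1Cl` gives 1080 nM in this assay
compound 3 `COc1cc(-c2nn(-c3cccc(NC(=O)Nc4cccc(C(F)(F)F)c4)c3)cc2-c2ccncc2)ccc1Cl` gives 886 nM in this assay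

Compound 3 sits at the low end of these three numbers: a 2.1-fold lower number from compound 1 to compound 3 (0.31 log units; beyond the scatter) lies beyond the scatter, whereas a 1.2-fold lower number from compound 2 to compound 3 (0.09 log units; within the scatter) lies within it, so compound 2 and compound 3 cannot be told apart.

Compound 4 `COc1cc(-c2nn(-c3cccc(NC(=O)Nc4ccc(Cl)c(C(F)(F)F)c4)c3)cc2-c2ccncc2)ccc1Cl` differs from compound 3 by chloro in place of hydrogen on an aromatic carbon. Among the compounds with values here, only one measured step touches this ring of the urea: a 1.2-fold lower number from compound 2 to compound 3 (0.09 log units; within the scatter), a change of the same ring that stayed within the scatter. The step of a 2.1-fold lower number from compound 1 to compound 3 (0.31 log units; beyond the scatter) concerns a different ring and offers no guide here. A small step at most is therefore expected, in either direction.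

Compound 4 is expected to give 700 nM, within 300 nM to 1800 nM, which would mean a 1.3-fold lower number from compound 3 to compound 4 (0.10 log units; within the scatter).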

Compound 4, concentration for 50% growth inhibition: 884 nM
Compound 4: middle estimate off by 1.3-fold (0.10 log units), on the low side; low and high end bracket the measured number.
By their numbers in this assay, from the lowest: compounds 4, 3, 2 and 1 (each within the scatter of the next, the first and the last beyond it).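

In this assay, chloro ortho to a trifluoromethyl group gives a 1.0-fold lower number from compound 3 to compound 4 (0.00 log units; within the scatter), so this position of the urea aryl ring accepts one more heavy atom without a readable change in growth inhibition. With the second trifluoromethyl group of compound 2, which gives a 1.2-fold lower number from compound 2 to compound 3 (0.09 log units; within the scatter), two different additions to this ring have now stayed within the scatter. Nothing available explains why the number holds steady. As far as these compounds go, whether an amine or a carboxylic acid at this position would shift the number remains open. So does whether chloro behaves the same without the neighbouring trifluoromethyl group.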